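Restoring an alkyl chain on the shared core

The source may report more compounds than this note shows. Statements on the series, on what has been measured and on what is new or still open speak of the compounds shown alone.

Compound 1 `CCCCCc1cc2nn(-c3ccccc3)cc2cn1`: 2100 nM
Compound 2 `CCCCc1cc2nn(-c3ccccc3)cc2c(C(C)C)n1`: 12900 nM
Compound 3 `OCCc1cc2nn(-c3ccccc3)cc2cn1`: > 100000 nM

The value for compound 3 in a functional assay on K562 cells (Homo sapiens) for inhibition, read by fluorescence, with a stated time of 72 h (a higher number here means a weaker inhibitor of growth, a lower number a stronger inhibitor of growth), is a limit of the assay and not a number (the limit of > 100000 nM in this assay, at which 1 of the 3 values shown sits). Compound 3 thus stands at the weak end of what these numbers show. Compound 4 `CCCCc1cc2nn(-c3ccccc3)cc2cn1` differs from it by ethyl in place of hydroxy on a saturated chain carbon, two bonds along the chain from an aromatic carbon. For the measured compounds named here, the one measured step that bears on this, an at least 47-fold higher number from compound 1 to compound 3 (1.67 log units; beyond the scatter), runs the other way: hydroxy taking the place of propyl raised the number greatly. Undoing that kind of change is expected to lower the number again, a large step back toward the value of compound 1. Compound 4 is therefore estimated at 3000 nM, between 1000 nM and 15000 nM. That is expected to be a step of an at least 33-fold lower number from compound 3 to compound 4 (1.52 log units; beyond the scatter).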

Compound 4, concentration for 50% growth inhibition: 6700 nM
Compound 4: middle estimate off by 2.2-fold (0.35 log units), on the low side, within the range that was stated.
By their numbers in this assay, from the lowest: compound 1; then compounds 4 and 2 (each within the scatter of the next). At a limit, above all of these: compound 3.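

The value of compound 3 is a limit and not a number: the limit of > 100000 nM in this assay, at which 1 of the 4 values shown sits. Butyl at this position nonetheless brings back a measurable value, with an at least 14-fold lower number from compound 3 to compound 4 (1.17 log units; beyond the scatter). Removing the chain's end methyl gives only a modest change, a 3.2-fold higher number from compound 1 to compound 4 (0.50 log units; beyond the scatter), while isopropyl on the aromatic carbon makes no readable difference, with a 1.9-fold lower number from compound 2 to compound 4 (0.28 log units; within the scatter).

The compounds shown leave open whether hydroxy at the end of a butyl chain would behave like 2-hydroxyethyl. They also leave open how an amine, a carboxylic acid or a chain longer than pentyl would read here.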